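The source may hold more compounds than are shown below. What is called first, only, known or untested is meant among the compounds shown, and "the series" means these compounds.

Going by the values given here, compound 2 `CC(C)OC(=O)N1CCC(COc2ccc(N3CCN(S(=O)(=O)C4CCCCC4)CC3)nc2)CC1` has the lower of the two numbers measured so far. In a functional assay on CHO-K1 cells for agonist activity at Glucose-dependent insulinotropic receptor (Homo sapiens), read by a luciferase reporter, with a stated time of 5 h (on this read-out lower numbers stand for an effect already at smaller amounts and higher numbers for an effect only at larger amounts of compound), compound 2 gives 200 nM, whereas compound 1 `CCS(=O)(=O)N1CCN(c2ccc(OCC3CCN(C(=O)OC(C)C)CC3)cn2)CC1` gives 1300 nM. Among the compounds with values here, the single measured step, a 6.5-fold lower number from compound 1 to compound 2 (0.81 log units; beyond the scatter), shows that exchanging the group on the sulfonyl sulfur shifted the read-out well beyond the scatter. Compound 3 `CC(C)OC(=O)N1CCC(COc2ccc(N3CCN(S(=O)(=O)CC4CCCCC4)CC3)nc2)CC1` differs from compound 2 by cyclohexylmethyl in place of cyclohexyl on a sulfonyl sulfur. Within the data shown here, that measured step bears on this change only in that it concerns the same position, the sulfonyl sulfur; it does not tell what moving the ring out by a cyclohexylmethyl link does, and no other compound addresses it. With the ring retained and attached at the same place, compound 3 is expected to stay near compound 2, with a step of a 1.3-fold higher number from compound 2 to compound 3 (0.10 log units; within the scatter) in this assay, not beyond the scatter. The estimate for compound 3 is therefore 250 nM, within a range from 80 nM to 800 nM.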

Compound 3, half-maximal effective concentration: 90 nM
Beside the measured number, compound 3's estimate is 2.8-fold (0.44 log units) above it, within the range that was stated.
By their numbers in this assay, from the lowest: compound 3; then compound 2; then compound 1.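

The position on the sulfonyl sulfur still responds once the ring is moved out by a cyclohexylmethyl link: in this assay the change gives a 2.2-fold lower number from compound 2 to compound 3 (0.35 log units; beyond the scatter) and this modest step lies beyond the scatter. The earlier pair compared only ethyl and cyclohexyl, whereas the wider comparison now gives a 14-fold lower number from compound 1 to compound 3 (1.16 log units; beyond the scatter) and so places cyclohexylmethyl lowest of the three groups on this read-out, with none of the three compounds going against that order. No measurement is at hand that explains why these numbers differ.

Going by these compounds, whether a longer chain such as cyclohexylethyl would lower the number further remains open. So does whether a benzyl group, with its phenyl ring in place of the cyclohexyl ring, would match cyclohexylmethyl at this position.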